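The compounds below may be only part of what the source reports. "The series", "measured", "known", "first", "only" and "open" are said of these compounds alone.

Compound 1 `COc1cc(C(=O)/C=C/c2cc(O)ccc2O)cc(OC)c1OC`: > 100000 nM
Compound 2 `COc1cc(C(=O)/C=C/c2cc([N+](=O)[O-])ccc2O)cc(OC)c1OC`: > 100000 nM

In a functional assay on HepG2 cells (Homo sapiens) for inhibition, read by MTT assay, with a stated time of 48 h (a higher number here means a weaker inhibitor, a lower number a stronger inhibitor), compound 1 gives > 100000 nM as a limit, not a number. Compound 2 gives > 100000 nM as a limit too. Compound 1 thus stands at the limit of > 100000 nM in this assay, at which 2 of the 2 values shown sit, and has no exact value. Compound 3 `COc1cc(C(=O)/C=C/c2ccccc2C=O)cc(OC)c1OC` differs from compound 1 as follows: 2-formylphenyl in place of 2,5-dihydroxyphenyl on a double-bonded chain carbon bound to a double-bonded chain carbon. Among the compounds with values here, only one measured step bears on this change. Because a step that the two limits leave unreadable from compound 1 to compound 2 offers no size to carry over, only a modest gain in this assay is expected, and another limit may well be reported. The expected change is an at least 1.4-fold lower number from compound 1 to compound 3 (0.15 log units; that floor lies within the scatter) in the direction of stronger inhibition. For compound 3 the estimate is 70000 nM with an expected range from 15000 nM to 200000 nM in this assay.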

Compound 3, half-maximal inhibitory concentration: > 100000 nM
Compound 3 ended at the assay's limit; the forecaster's own chance of this, stated with the estimate: 50%; at least 1.4-fold (0.15 log units) between middle value and limit.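

No size can be read for the step from compound 1 to compound 3, since both compounds end at a limit rather than a number: the limit of > 100000 nM in this assay, at which 3 of the 3 values shown sit. The compounds shown leave open how strongly any of them inhibits in this assay, and whether swapping these groups matters at all.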